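Moving the Halogen and Lengthening the Chain

A few compounds are considered here, and "the series" means these few. Any claim that something is new, unique, unknown or untested is made for them only; others in the source may bear on it.

In a functional assay on HPAC cells (Homo sapiens) for inhibition, read by MTT assay, with a stated time of 72 h (on this read-out lower numbers stand for stronger inhibition of growth and higher numbers for weaker inhibition of growth), compound 1 `O=S(=O)(NCCCNCc1ccccc1Cl)c1cc(C(F)(F)F)cc(C(F)(F)F)c1` gives 10000 nM, the highest number of the three measured compounds. Compound 2 `CC(C)(C)c1ccc(CNCCCNS(=O)(=O)c2cc(C(F)(F)F)cc(C(F)(F)F)c2)cc1` gives 2300 nM and compound 3 `O=S(=O)(NCCNCc1ccc(-c2ccccc2)cc1)c1cc(C(F)(F)F)cc(C(F)(F)F)c1` gives 2800 nM. Going by the values given here, only one measured step changes a single place: a 4.3-fold lower number from compound 1 to compound 2 (0.64 log units; beyond the scatter). Compound 4 `O=S(=O)(NCCCCNCc1ccc(Br)cc1)c1cc(C(F)(F)F)cc(C(F)(F)F)c1` differs from compound 1 as follows: ((4-bromobenzyl)amino)methyl in place of (2-chlorobenzyl)amino on a saturated chain carbon, three bonds along the chain from a sulfonamide nitrogen. Among the compounds with values here, as in that step, the 2-chlorobenzyl leaves, but a 4-bromobenzyl enters rather than a 4-(tert-butyl)benzyl, and the chain gains one carbon; no measured step covers either of these alone. Because the step of a 4.3-fold lower number from compound 1 to compound 2 (0.64 log units; beyond the scatter) lowered the number, compound 4 is expected to show a smaller drop, a 2.2-fold lower number from compound 1 to compound 4 (0.35 log units; beyond the scatter). Compound 4 is estimated at 4500 nM, within a range from 1500 nM to 13000 nM.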

Compound 4, concentration for 50% growth inhibition: 2000 nM
Beside the measured number, compound 4's estimate is 2.3-fold (0.35 log units) above it; low and high end bracket the measured number.
By their numbers in this assay, from the lowest: compounds 4, 2 and 3 (each within the scatter of the next); then compound 1.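

In this assay, a 5.0-fold lower number from compound 1 to compound 4 (0.70 log units; beyond the scatter) shows that the 2-chlorobenzyl group can be replaced by a second group, not only the 4-(tert-butyl)phenyl of compound 2, with a drop beyond the scatter. This step swaps the benzyl group and lengthens the chain at once, so the share of each change cannot be separated. Nothing available explains the drop.

Still open, from the compounds shown here alone, is how a 4-bromobenzyl group would behave on the shorter chain of compound 1. Also open, going by these compounds, is what a longer chain or an amide in place of the amine would do.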